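A few compounds are considered here, and "the series" means these few. Any claim that something is new, unique, unknown or untested is made for them only; others in the source may bear on it.

Measured so far:

Compound 1, `O=C(O)CCC/C=C\C[C@H]1/C(=N/OC(c2ccccc2)c2ccccc2)CC[C@@H]1NS(=O)(=O)c1ccc(F)cc1`: in a functional assay (plasma) for inhibition, with Homo sapiens as the target (a lower number here means a stronger inhibitor, a higher number a weaker inhibitor), compound 1 gives 17000 nM.
Compound 2, `Cc1ccc(S(=O)(=O)N[C@H]2CC/C(=N\OC(c3ccccc3)c3ccccc3)[C@@H]2C/C=C\CCCC(=O)O)cc1`: in this assay compound 2 gives 5600 nM.
Compound 3, `O=C(O)CCC/C=C\C[C@@H]1[C@H](O)CC[C@H]1NS(=O)(=O)c1ccc(F)cc1`: in this assay compound 3 gives 6000 nM.

Compound 1 and compound 2 share one core and differ in a single place, (methyl in place of fluoro on an aromatic carbon). That change made a step of a 3.0-fold lower number from compound 1 to compound 2 (0.48 log units; beyond the scatter) in this assay. Compound 3 has a different core; how its core differs from that of compound 1 is not broken down here. Compound 3 and compound 2 lie within the scatter of each other, while compound 3 stands beyond the scatter from compound 1.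

Compound 4, `Cc1ccc(S(=O)(=O)N[C@@H]2CC[C@@H](O)[C@H]2C/C=C\CCCC(=O)O)cc1`, is not yet measured. It stands to compound 3 as compound 2 stands to compound 1: methyl in place of fluoro on an aromatic carbon. The place is described in the same words in both pairs, so it is the same change, made on a different core. The expectation for compound 4 rests on compound 1 and compound 2, whose step was a 3.0-fold lower number from compound 1 to compound 2 (0.48 log units; beyond the scatter), and on the value of compound 3, which is 6000 nM. For the measured compounds named here, only one such step is known, and it was made on another core. The expected step from compound 3 to compound 4 in this assay is taken as a 2.4-fold lower number from compound 3 to compound 4 (0.38 log units; beyond the scatter), with wide bounds. Compound 4 is therefore estimated at 2500 nM, between 900 nM and 7000 nM.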

Compound 4, half-maximal inhibitory concentration: 5800 nM
For compound 4 the middle estimate is 2.3-fold (0.37 log units) below the measured one; the measured number falls inside the stated range.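

In this assay, for the compounds shown here, putting methyl in place of fluoro on the core of compound 3, the change from 4-fluorophenyl to 4-methylphenyl, gave a 1.0-fold lower number from compound 3 to compound 4 (0.01 log units; within the scatter), so on this core the change left no step that can be told from the scatter. Going by these compounds alone, the change therefore did not carry over in size from the core of compound 1 to the core of compound 3, and a step seen on one core cannot simply be transferred to the other: the same change on two cores in this assay, a 3.0-fold lower number (0.48 log units; beyond the scatter) from compound 1 to compound 2 and a 1.0-fold lower number (0.01 log units; within the scatter) from compound 3 to compound 4, 2.9-fold (0.47 log units) apart, beyond the scatter of two such steps This rests on only two pairs of compounds, so it shows that the size of the step depends on the core in these pairs, but it does not show which part of the core is responsible, why the step differs, or what size the step would take on a third core.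

The compounds shown leave open whether other groups in the same place on the aromatic ring, such as chloro, methoxy or a nitrile, would give a step on either core. They also leave open how this change would behave with an amide in place of the carboxylic acid or with a shorter chain carrying that acid.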